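The source may report more compounds than this note shows. Statements on the series, on what has been measured and on what is new or still open speak of the compounds shown alone.

Measured compounds:
- compound 1, `COc1ccccc1N1CCN(CCCCC(=O)NCc2ccccc2-c2c(OC)cccc2OC)CC1`: 32.4 nM
- compound 2, `COc1ccccc1N1CCN(CCCC(=O)NCc2ccccc2-c2ccccc2)CC1`: 64.5 nM

Of the compounds shown here, two have been measured in an assay on CHO-K1 cells for displacement of a labelled ligand from 5-hydroxytryptamine receptor 7 (Homo sapiens), read by scintillation counting; a higher number here means a weaker inhibitor, a lower number a stronger inhibitor. Compound 1 gives 32.4 nM and compound 2 gives 64.5 nM. These two numbers sit within the usual scatter of each other, so on this evidence the two compounds cannot be told apart.

Compound 3, `COc1ccccc1N1CCN(CCCCC(=O)NCc2ccccc2-c2ccc(C)cc2)CC1`, has not yet been measured in this assay. It is built from compound 1 with one change: 4-methylphenyl in place of 2,6-dimethoxyphenyl on an aromatic carbon. Both groups are a single six-membered aromatic ring of carbon only, but the entering group carries no hydrogen-bond acceptors and fewer heavy atoms than the one it replaces. Among the measured compounds shown here, no pair of measured compounds shows the effect of such a change, so the expectation rests on compound 1 alone. A modest move to a higher number is expected, of a size that may not stand out from the scatter: a 1.7-fold higher number from compound 1 to compound 3 (0.23 log units; within the scatter). Compound 3 is therefore estimated at 55 nM, with a range from 15 nM to 200 nM.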

Compound 3, inhibition constant: 66.1 nM
Compound 3: the middle estimate sits 1.2-fold (0.08 log units) below what was measured, within the range that was stated.
By their numbers in this assay, from the lowest: compounds 1, 2 and 3 (each within the scatter of the next, the first and the last beyond it).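

In this assay, among the compounds shown here, putting 4-methylphenyl in place of 2,6-dimethoxyphenyl gives a 2.0-fold higher number from compound 1 to compound 3 (0.31 log units; beyond the scatter), the first step here that changes only one place. It shows that this place, an aromatic carbon ortho to a large group, responds modestly to this swap, even though the entering group has no hydrogen-bond acceptors and fewer heavy atoms than the one it replaces. Nothing measured here explains the shift.

The swap removes both methoxy groups and adds a methyl group in a single step, so the compounds shown leave open which of these differences matters. Also open, as far as these compounds go, is how the number would respond at this place to another group, such as 4-chlorophenyl or a pyridine ring.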